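The source may hold more compounds than are shown below. What is called first, only, known or untested is meant among the compounds shown, and "the series" means these compounds.

Working notes on the series.

Compound 1 `COc1ccccc1-n1cc(COc2c(/C=C\C(=O)O)ccc(OC)c2CC=C(C)C)nn1` has no result reported in a functional assay on PC-3 cells (Homo sapiens) for cytotoxicity, read by MTT assay, with a stated time of 24 h; a lower number here means a stronger inhibitor, a higher number a weaker inhibitor; its entry stands as "not determined" (no result reported). Compound 3 `COc1cccc(-n2cc(COc3c(/C=C\C(=O)O)ccc(OC)c3CC=C(C)C)nn2)c1` likewise has no result reported, its entry in this assay being "not determined" (no result reported); for these two nothing can be said beyond the structures themselves. Within the data shown here, compound 2 `COc1ccc(/C=C\C(=O)O)c(OCc2cn(-c3ccccc3F)nn2)c1CC=C(C)C` is the only member of the series with a number: in this assay compound 2 gives 24200 nM, which marks it as a weak inhibitor, and with no second number it cannot be placed above or below anything else.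

Compound 4 `COc1ccc(/C=C\C(=O)O)c(OCc2cn(-c3ccccc3C(=O)N3CCC(O)C3)nn2)c1CC=C(C)C` is the next member to be measured. It differs from compound 2 by a single replacement: (3-hydroxypyrrolidin-1-yl)carbonyl in place of fluoro on an aromatic carbon. Among the measured compounds shown here, no pair of measured compounds shows what such a change does, so the direction of the step has nothing to rest on.

With only compound 2 as an anchor at 24200 nM, the expectation for compound 4 is a step from compound 2 to compound 4 of a 1.0-fold higher number from compound 2 to compound 4 (0.01 log units; within the scatter), meaning no change beyond the usual scatter. Compound 4 is therefore estimated at 25000 nM in this assay, with a range from 8000 nM to 80000 nM, the width reflecting the absence of any guiding step.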

Compound 4, half-maximal inhibitory concentration: 36200 nM
For compound 4 the middle estimate is 1.4-fold (0.16 log units) below the measured one, and the stated range covers the measured number.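

In this assay, among these compounds, the first readable step, a 1.5-fold higher number from compound 2 to compound 4 (0.17 log units; within the scatter), stays within the usual scatter, so at this aromatic carbon, ortho to a large group, the two groups cannot be told apart. The entering (3-hydroxypyrrolidin-1-yl)carbonyl brings a five-membered non-aromatic ring, a hydrogen-bond donor and hydrogen-bond acceptors that fluoro lacks, yet this exchange gives no separation beyond the scatter in this read-out. No measured evidence bears on this result.

Steps involving compound 1 and compound 3 cannot be read, so the methoxy compounds add nothing to this comparison. On these data alone, whether a primary amine or a carboxylic acid on the same carbon would move the number beyond the scatter stays open, as does the outcome for a plain dimethylamide carbonyl without the hydroxy-bearing ring.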